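The compounds below may be only part of what the source reports. "The series", "measured", "known", "first", "only" and "open" are said of these compounds alone.

Measured so far in a physicochemical assay for lipophilicity, read by HPLC, measured as octanol-water partition; on this read-out lower numbers stand for lower lipophilicity and higher numbers for higher lipophilicity:
compound 1, `O=C1CSC(=O)N1C[C@H]1CN(c2ccc(-n3cc(-c4ccccn4)cn3)c(F)c2)C(=O)O1`, 2.18
compound 2, `CS(=O)(=O)NC[C@H]1CN(c2ccc(-n3cc(-c4ccccn4)cn3)c(F)c2)C(=O)O1`, 1.38

Going by the values given here, compound 2 stands at the lower of the two numbers so far; compound 1 sits above it by a number 0.80 log units lower from compound 1 to compound 2 (beyond the scatter), a step that goes beyond the usual scatter.

Compound 3, `NC(=O)[C@H]1CN(c2ccc(-n3cc(-c4ccccn4)cn3)c(F)c2)C(=O)O1`, has not been measured. It differs from compound 2 as follows: carbamoyl in place of (methanesulfonamido)methyl on a saturated ring carbon. The whole side chain is thus replaced by a shorter group carrying fewer heavy atoms and one acceptor fewer.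

Among the compounds with values here, only one measured step bears on this: the change from compound 1 to compound 2, which exchanged the group on that side chain and lowered this assay by a number 0.80 log units lower from compound 1 to compound 2 (beyond the scatter). Within the data shown here, no step of the present kind has been measured, so the size is uncertain. Exchanging the side chain for a carbamoyl is expected to keep this assay near or somewhat under the number for compound 2, an estimated step of a number 0.23 log units lower from compound 2 to compound 3 (within the scatter). For compound 3 this assay is therefore estimated at 1.15, within a range from 0.6 to 1.7.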

Compound 3, partition coefficient: 1.59
For compound 3 the middle estimate is 0.44 log units below the measured one, and the stated range covers the measured number.
By their numbers in this assay, from the lowest: compounds 2 and 3 (each within the scatter of the next); then compound 1.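

In this assay, carbamoyl in place of (methanesulfonamido)methyl on the saturated ring carbon gives a number 0.21 log units higher from compound 2 to compound 3 (within the scatter), so at this position a group of 3 heavy atoms attached directly to the ring and a group of 6 heavy atoms on a chain read alike. Compared with the (2,4-dioxo-1,3-thiazolidin-3-yl)methyl group, the same carbamoyl gives a number 0.59 log units lower from compound 1 to compound 3 (beyond the scatter), which leaves compound 1 apart from both compound 2 and compound 3 and shows that two quite different replacements for its group land at similar readings on the shared core. No measurement in hand accounts for these readings.

Open, from the compounds shown here alone, is how a primary amine or a carboxylic acid on that saturated ring carbon would read in this assay, and whether a longer chain ending in the carbamoyl would stay with compound 2 and compound 3 or move toward compound 1. Also open, going by these compounds, is whether the close agreement between carbamoyl and (methanesulfonamido)methyl would hold on a core other than the shared one.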